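Compound 3 to compound 4: chloro for cyano

A few compounds are considered here, and "the series" means these few. Any claim that something is new, unique, unknown or untested is made for them only; others in the source may bear on it.

In a functional assay on NCI-H460 cells (Homo sapiens) for antiproliferative activity, with a stated time of 72 h (a lower number here means a stronger inhibitor, a higher number a weaker inhibitor), compound 1 `C=CC[C@H]1C[C@]2([C@@H](C)Cc3ccc(OC)cc3)OCOC2=CC1=O` gives 90 nM, compound 2 `C=CC[C@H]1C[C@]2([C@@H](C)Cc3ccc(OC)c(C(N)=O)c3)OCOC2=CC1=O` gives 66 nM and compound 3 `C=CC[C@H]1C[C@]2([C@@H](C)Cc3ccc(OC)c(C#N)c3)OCOC2=CC1=O` gives 340 nM. Compound 3 carries the highest number of the three, and its gaps to both others lie beyond the scatter.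

The next compound is compound 4 `C=CC[C@H]1C[C@]2([C@@H](C)Cc3ccc(OC)c(Cl)c3)OCOC2=CC1=O`. The change is chloro in place of cyano on an aromatic carbon.

Going by the values given here, no measured step brings in chloro, so the evidence is indirect. Cyano in place of hydrogen gave a 3.8-fold higher number from compound 1 to compound 3 (0.58 log units; beyond the scatter), and cyano in place of carbamoyl gave a 5.2-fold higher number from compound 2 to compound 3 (0.71 log units; beyond the scatter). Carbamoyl in place of hydrogen gave a 1.4-fold lower number from compound 1 to compound 2 (0.13 log units; within the scatter), which stays within the scatter. From the compounds shown here alone, removing the cyano is therefore expected to bring the number back towards that of compound 1 at 90 nM, though chloro itself remains untested.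

The expected modest move to a lower number in this assay is a 2.8-fold lower number from compound 3 to compound 4 (0.45 log units; beyond the scatter). Compound 4 is estimated at 120 nM, with an expected range of 50 nM to 300 nM.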

Compound 4, half-maximal inhibitory concentration: 640 nM
Compound 4: the middle estimate sits 5.3-fold (0.73 log units) below what was measured, outside the stated range (above it).
By their numbers in this assay, from the lowest: compounds 2 and 1 (each within the scatter of the next); then compounds 3 and 4 (each within the scatter of the next).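

In this assay, chloro on the aromatic carbon ortho to a methoxy group cannot be told apart from cyano (a 1.9-fold higher number from compound 3 to compound 4 (0.27 log units; within the scatter)), so the higher numbers at this carbon do not belong to the nitrile alone. Chloro stands clear of both hydrogen (a 7.1-fold higher number from compound 1 to compound 4 (0.85 log units; beyond the scatter)) and carbamoyl (a 9.7-fold higher number from compound 2 to compound 4 (0.99 log units; beyond the scatter)), which leaves carbamoyl as the only one of the three substituents here that stays level with hydrogen. Nothing measured on these compounds accounts for this split.

From the compounds shown here alone, whether that level result is particular to carbamoyl remains open, and a hydroxyl, an amine or a carboxylic acid on the same carbon would test it. The compounds shown also leave open whether chloro and carbamoyl would keep this order on another carbon of the aromatic ring.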